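Compound 3 to compound 4: adding a propyl group

This account rests on a few compounds, and the source may have more. Where it says the series, first, only, none or still open, it means among the compounds named here.

In a functional assay on ileum (Cavia porcellus) for antagonist activity (on this read-out lower numbers stand for stronger inhibition and higher numbers for weaker inhibition), three compounds on a shared core have been measured. Compound 1 `COc1ccc(OCCCOc2ccc3c(O)c([N+](=O)[O-])c(=O)oc3c2)cc1` reports > 4000 nM, which is a limit of the assay and not a number. Compound 2 `Cc1ccc(OCCCOc2ccc3c(O)c([N+](=O)[O-])c(=O)oc3c2)cc1` gives 4500 nM. Compound 3 `CC(=O)c1ccc(OCCCOc2ccc3c(O)c([N+](=O)[O-])c(=O)oc3c2)cc1O` gives 2800 nM. Within the data shown here, the only fully readable comparison for this last value is a 1.6-fold lower number from compound 2 to compound 3 (0.21 log units; within the scatter), so the two numbers cannot be ranked. The comparison with the limit, an at least 1.4-fold lower number from compound 1 to compound 3 (0.15 log units; that floor lies within the scatter), does not separate them either.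

Compound 4 `CCCc1c(OCCCOc2ccc3c(O)c([N+](=O)[O-])c(=O)oc3c2)ccc(C(C)=O)c1O` is the next entry, and it carries propyl in place of hydrogen on an aromatic carbon. This places propyl in place of hydrogen on an aromatic carbon, ortho to a hydroxy group and meta to an acetyl group.

Both measured steps that reach compound 3 replace the whole substituted phenyl group, with 4-acetyl-3-hydroxyphenyl entering. Among the measured compounds shown here, neither adds propyl, and no measured compound tests this change. They therefore give no direct size for it, only a starting point at compound 3 with 2800 nM. A move toward a lower number in this assay is expected, on thin ground and with a wide margin. The expected size is a 3.1-fold lower number from compound 3 to compound 4 (0.49 log units; beyond the scatter). For compound 4 the estimated value is 900 nM, with an expected range of 150 nM to 3500 nM.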

Compound 4, half-maximal inhibitory concentration: 100 nM
Compound 4: middle estimate off by 9.0-fold (0.95 log units), on the high side; the measured number lies below the stated range.
By their numbers in this assay, from the lowest: compound 4; then compounds 3 and 2 (each within the scatter of the next).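

In this assay, among these compounds, the aromatic carbon ortho to a hydroxy group and meta to an acetyl group turns out to be a place where one small change moves the read-out strongly: propyl in place of hydrogen gives a 28-fold lower number from compound 3 to compound 4 (1.45 log units; beyond the scatter), the first readable step beyond the scatter. The earlier readable comparisons replaced the whole substituted phenyl group and stayed within the scatter, so they gave no sign that this position could matter so much. Nothing measured here bears on why the step is so large.

Whether the effect belongs to propyl specifically or would appear with other groups at this carbon remains open: only hydrogen and propyl are shown there, and methyl, ethyl, butyl or an amine at the same place would begin to separate these readings. Also open, going by these compounds, is how far the step depends on its neighbours, as propyl appears only alongside the hydroxy and acetyl groups of compound 4, and a carboxylic acid in place of that acetyl group would be one test.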